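Shortening the hydroxyalkyl chain on a naphthyl urea

The source may report more compounds than this note shows. Statements on the series, on what has been measured and on what is new or still open speak of the compounds shown alone.

Compound 1 `CCCC(O)Cn1ncc(C(=O)OCC)c1NC(=O)NC(C)C` and compound 2 `CCOC(=O)c1cnn(CC(O)CC)c1NC(=O)Nc1cccc2ccccc12` were both tested in a functional assay on cells (Neutrophil, Homo sapiens) for inhibition, with a stated time of 10 min; a higher number here means a weaker inhibitor, a lower number a stronger inhibitor. Compound 1 gives 20 nM in this assay, and compound 2 gives 12 nM; the difference between the two cores is not broken down here. Compound 3 `CCOC(=O)c1cnn(CC(O)CC)c1NC(=O)NC(C)C` in this assay gives only a limit, > 10 nM. The change from compound 1 to compound 3 is hydrogen in place of methyl on a saturated chain carbon, three bonds along the chain from an oxygen on a saturated carbon, and a step that the limit leaves unreadable from compound 1 to compound 3 because of the limit of > 10 nM in this assay, at which 1 of the 3 values shown sits. Compound 4 `CCOC(=O)c1cnn(CC(C)O)c1NC(=O)Nc1cccc2ccccc12` carries the same kind of change against compound 2, (hydrogen in place of methyl on a saturated chain carbon, two bonds along the chain from an oxygen on a saturated carbon), though here the place is two bonds rather than three bonds along the chain from the oxygen. With no readable step of this kind measured, the expected step from compound 2 to compound 4 is a 1.5-fold higher number from compound 2 to compound 4 (0.18 log units; within the scatter), resting on compound 2 at 12 nM. Compound 4 is therefore estimated at 18 nM, between 7 nM and 45 nM.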

Compound 4, half-maximal inhibitory concentration: 9.8 nM
Compound 4: the middle estimate sits 1.8-fold (0.26 log units) above what was measured, and the stated range covers the measured number.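

On the core of compound 2, going from 2-hydroxybutyl to 2-hydroxypropyl in this assay gives a 1.2-fold lower number from compound 2 to compound 4 (0.09 log units; within the scatter), so this one pair shows no readable change. Compound 3 gives only a limit, > 10 nM. The step from compound 1 to compound 3 therefore cannot be read, and it also lies three bonds rather than two along the chain from the oxygen, so nothing here shows whether the result carries from one core to another: the limit of > 10 nM in this assay, at which 1 of the 4 values shown sits.

The compounds shown leave open how this assay responds to an amine or a carboxylic acid in place of the hydroxyl. They also leave open what a chain longer than 2-hydroxybutyl would give on the core of compound 2.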